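The source may hold more compounds than are shown below. What is called first, only, known or untested is meant among the compounds shown, and "the series" means these compounds.

Compound 2 `CCS(=O)(=O)Nc1cc(-c2ccc3ncnc(Nc4ccc(OC)c(OC)c4)c3c2)cnc1OC` gives 2840 nM in a functional assay on SK-HEP1 cells (Homo sapiens) for cytotoxicity, read by sulforhodamine B assay, with a stated time of 72 h; a higher number here means a weaker inhibitor, a lower number a stronger inhibitor; compound 1 `CCS(=O)(=O)Nc1cc(-c2ccc3ncnc(Nc4ccc(F)cc4)c3c2)cnc1OC` gives 1470 nM, and the two lie within the scatter of each other, as the step of a 1.9-fold higher number from compound 1 to compound 2 (0.29 log units; within the scatter) shows. Compound 3 `CCS(=O)(=O)Nc1cc(-c2ccc3ncnc(Nc4ccc(OC)c(Cl)c4)c3c2)cnc1OC` differs from compound 2 by chloro in place of methoxy on an aromatic carbon. For the measured compounds named here, no measured step covers this change; the only step in hand is the aryl swap from compound 1 to compound 2, which stayed within the scatter. For compound 3 the expected step of a 1.1-fold lower number from compound 2 to compound 3 (0.06 log units; within the scatter) is therefore no more than the scatter. Compound 3 is estimated at 2500 nM, between 1000 nM and 6000 nM.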

Compound 3, half-maximal inhibitory concentration: 2810 nM
Estimate against measurement, compound 3: 1.1-fold (0.05 log units) below; measured number inside the range.
By their numbers in this assay, from the lowest: compounds 1, 3 and 2 (each within the scatter of the next).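

In this assay, for the compounds shown here, chloro in place of methoxy on this aromatic carbon, ortho to a methoxy group, gives a 1.0-fold lower number from compound 2 to compound 3 (0.00 log units; within the scatter) and is the first reading of a change at this position. The step of a 1.9-fold higher number from compound 1 to compound 3 (0.28 log units; within the scatter) also stays within the scatter, so the 4-fluorophenyl, 3,4-dimethoxyphenyl and 3-chloro-4-methoxyphenyl compounds cannot be told apart here. No evidence bears on why these numbers sit so close. On these data alone, whether an amine, a carboxylic acid or a longer chain such as butoxy at this position would move the number beyond the scatter remains open.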